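This account rests on a few compounds, and the source may have more. Where it says the series, first, only, none or still open, it means among the compounds named here.

In a functional assay on HeLa cells (Homo sapiens) for antiproliferative activity, read by MTT assay, with a stated time of 72 h (on this read-out higher numbers stand for weaker inhibition and lower numbers for stronger inhibition), three compounds share one core and differ in the group on an aromatic nitrogen. With 4-methylphenyl, compound 1 `CCCNC(=O)c1cc(Oc2ccc(NC(=O)c3nn(-c4ccc(C)cc4)c(=O)cc3C)cc2F)ccn1` gives 14200 nM as its result. With 4-bromo-2-fluorophenyl, compound 2 `CCCNC(=O)c1cc(Oc2ccc(NC(=O)c3nn(-c4ccc(Br)cc4F)c(=O)cc3C)cc2F)ccn1` gives 53500 nM as its result. With 2-(trifluoromethoxy)phenyl, compound 3 `CCCNC(=O)c1cc(Oc2ccc(NC(=O)c3nn(-c4ccccc4OC(F)(F)F)c(=O)cc3C)cc2F)ccn1` gives 3690 nM and holds the lowest of the three numbers, so it inhibits most strongly here.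

Compound 4 `CCCNC(=O)c1cc(Oc2ccc(NC(=O)c3nn(-c4cccc(C(F)(F)F)c4)c(=O)cc3C)cc2F)ccn1` changes that group once more, and 3-(trifluoromethyl)phenyl in place of 2-(trifluoromethoxy)phenyl on an aromatic nitrogen is the whole difference. Among the compounds with values here, three measured steps touch this same spot: a 3.8-fold higher number from compound 1 to compound 2 (0.58 log units; beyond the scatter) and a 3.8-fold lower number from compound 1 to compound 3 (0.59 log units; beyond the scatter) are modest, and a 14-fold lower number from compound 2 to compound 3 (1.16 log units; beyond the scatter) is large. Within the data shown here, a swap here is therefore unlikely to pass unnoticed, yet no measured compound carries 3-(trifluoromethyl)phenyl, so the direction remains uncertain. Compound 3 at 3690 nM is the low point of the series and both other groups sit higher, which favours a rise. In this assay a modest rise is expected, with a 2.4-fold higher number from compound 3 to compound 4 (0.39 log units; beyond the scatter) as the estimated step. For compound 4 the estimated value is 9000 nM within a range of 2500 nM to 35000 nM overall.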

Compound 4, half-maximal inhibitory concentration: 8000 nM
Beside the measured number, compound 4's estimate is 1.1-fold (0.05 log units) above it; the measured number falls inside the stated range.
By their numbers in this assay, from the lowest: compound 3; then compounds 4 and 1 (each within the scatter of the next); then compound 2.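

In this assay, the 3-(trifluoromethyl)phenyl group brings a 2.2-fold higher number from compound 3 to compound 4 (0.34 log units; beyond the scatter), so 2-(trifluoromethoxy)phenyl keeps the lowest number seen at this position, while a 6.7-fold lower number from compound 2 to compound 4 (0.83 log units; beyond the scatter) shows that the new group stays well clear of the 4-bromo-2-fluorophenyl result. With a 1.8-fold lower number from compound 1 to compound 4 (0.25 log units; within the scatter), the new group cannot be told apart from 4-methylphenyl, so this change adds a second group to the middle of the series rather than a new extreme. Nothing available here explains these differences.

The change from compound 3 to compound 4 alters both the group and where it sits on the phenyl ring, so 2-(trifluoromethyl)phenyl and 3-(trifluoromethoxy)phenyl would be needed to separate those two effects. From the compounds shown here alone, how a phenyl ring carrying an amine or a carboxylic acid would behave at this position also remains open.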